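The source may hold more compounds than are shown below. What is called first, only, known or untested is meant among the compounds shown, and "the series" means these compounds.

Working notes on a small series assessed in a functional assay on HepG2 cells (Homo sapiens) for inhibition, read by MTT assay, with a stated time of 72 h; on this read-out lower numbers stand for stronger inhibition and higher numbers for weaker inhibition. Compound 1 `O=[N+]([O-])c1ccc(-c2nnc(SCCCN3CCN(c4nc5ccccc5o4)CC3)o2)cc1` gives 67200 nM in this assay. Compound 2 `Cc1ccc(-c2nnc(SCCCN3CCN(c4nc5ccccc5o4)CC3)o2)cc1` gives 154000 nM. The single difference between these two is methyl in place of nitro on an aromatic carbon, and it produces a 2.3-fold higher number from compound 1 to compound 2 (0.36 log units; beyond the scatter). Compound 3 `O=[N+]([O-])c1ccc(-c2nnc(SCCCN3CCN(c4nc5ccccc5s4)CC3)o2)cc1` gives 93300 nM. Its core differs from the core of compound 1 by 1,3-benzothiazol-2-yl in place of 1,3-benzoxazol-2-yl on an amine nitrogen in a ring. This core change produces a 1.4-fold higher number from compound 1 to compound 3 (0.14 log units; within the scatter), so the two cores behave alike in this assay on the evidence so far.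

Compound 4 `Cc1ccc(-c2nnc(SCCCN3CCN(c4nc5ccccc5s4)CC3)o2)cc1` has not yet been measured. Going by the values given here, it differs from compound 3 by methyl in place of nitro on an aromatic carbon, which is the same change, at the same place, as the one separating compound 1 from compound 2; it occurs twice. Among the compounds with values here, only one measured instance of the change exists, so the expectation rests on that instance alone, carried over to the second core. The step from compound 3 to compound 4 is estimated as a 2.1-fold higher number from compound 3 to compound 4 (0.33 log units; beyond the scatter), beside the earlier 2.3-fold higher number from compound 1 to compound 2 (0.36 log units; beyond the scatter). Compound 4 is accordingly expected to give 200000 nM, with a likely range from 110000 nM to 380000 nM.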

Compound 4, half-maximal inhibitory concentration: 96700 nM
Estimate against measurement, compound 4: 2.1-fold (0.32 log units) above, and the stated range ends above it.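

In this assay, methyl in place of nitro on the aromatic carbon gives a 1.0-fold higher number from compound 3 to compound 4 (0.02 log units; within the scatter) on the core of compound 3, and this step cannot be told apart from the one on the core of compound 1: the same change on two cores in this assay, a 2.3-fold higher number (0.36 log units; beyond the scatter) from compound 1 to compound 2 and a 1.0-fold higher number (0.02 log units; within the scatter) from compound 3 to compound 4, 2.2-fold (0.34 log units) apart, within the scatter of two such steps. The reverse reading agrees, with 1,3-benzothiazol-2-yl in place of 1,3-benzoxazol-2-yl giving a 1.6-fold lower number from compound 2 to compound 4 (0.20 log units; within the scatter) in the methyl pair, again not separable from the same change in the nitro pair: the same change on two cores in this assay, a 1.4-fold higher number (0.14 log units; within the scatter) from compound 1 to compound 3 and a 1.6-fold lower number (0.20 log units; within the scatter) from compound 2 to compound 4, 2.2-fold (0.34 log units) apart, within the scatter of two such steps. Carrying either change from one core to the other is therefore not contradicted, but with one pair per core this shows neither that the step keeps a fixed size nor that it depends on the core.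

On these data alone, it remains open whether an amine, a carboxylic acid or a methoxy group in place of nitro on the same aromatic carbon would follow either step. A longer chain on the sulfur is also untested in these compounds on either core.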